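Halogen returns at the para position: compound 4 estimated

This account rests on a few compounds, and the source may have more. Where it says the series, first, only, none or still open, it means among the compounds named here.

Compound 1 `Nc1ccccc1NC(=O)c1ccc(COc2ccc(Br)cc2)cc1` gives 24400 nM in a functional assay on A549 cells (Homo sapiens) for antiproliferative activity, read by CCK-8 assay, with a stated time of 72 h; on this read-out higher numbers stand for weaker inhibition and lower numbers for stronger inhibition. Compound 2 `Nc1ccccc1NC(=O)c1ccc(COc2ccccc2)cc1` gives 6760 nM, and compound 3 `CCCc1ccc(OCc2ccc(C(=O)Nc3ccccc3N)cc2)cc1` gives 5210 nM; compound 3 stands apart from compound 1 by a 4.7-fold lower number from compound 1 to compound 3 (0.67 log units; beyond the scatter), while its number and that of compound 2 lie within the scatter of each other, so neither can be placed ahead of the other. Compound 4 `Nc1ccccc1NC(=O)c1ccc(COc2ccc(F)cc2)cc1` differs from compound 3 by fluoro in place of propyl on an aromatic carbon. The bearing steps are a 4.7-fold lower number from compound 1 to compound 3 (0.67 log units; beyond the scatter) and a 3.6-fold lower number from compound 1 to compound 2 (0.56 log units; beyond the scatter), both of which show a halogen at this place going with a higher number, whereas a 1.3-fold lower number from compound 2 to compound 3 (0.11 log units; within the scatter) shows little. Compound 4 is therefore expected to return part of the way toward compound 1, with a step of a 2.1-fold higher number from compound 3 to compound 4 (0.32 log units; beyond the scatter). Compound 4 is estimated at 11000 nM, in the range 5000 nM to 25000 nM.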

Compound 4, half-maximal inhibitory concentration: 5370 nM
For compound 4 the middle estimate is 2.0-fold (0.31 log units) above the measured one, and the stated range covers the measured number.
By their numbers in this assay, from the lowest: compounds 3, 4 and 2 (each within the scatter of the next); then compound 1.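

In this assay the 4-fluorophenyl compound undoes the link between a halogen at this place and a higher number, since a 1.0-fold higher number from compound 3 to compound 4 (0.01 log units; within the scatter) and a 1.3-fold lower number from compound 2 to compound 4 (0.10 log units; within the scatter) leave fluoro, propyl and hydrogen unseparated. Bromo alone stands apart among the four, with a 4.5-fold lower number from compound 1 to compound 4 (0.66 log units; beyond the scatter), so the higher number goes with compound 1 and not with halogens as a whole. Nothing shown accounts for this difference between fluoro and bromo. On these data alone, whether chloro sides with fluoro or with bromo stays open, as does the reading of an amine or a carboxylic acid at this place.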